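Isobutyl in place of butyl at the assay limit

This account rests on a few compounds, and the source may have more. Where it says the series, first, only, none or still open, it means among the compounds named here.

In a functional assay on L02 cells (Homo sapiens) for inhibition, read by Griess assay, with stated times of 1 h and 24 h (on this read-out higher numbers stand for weaker inhibition and lower numbers for stronger inhibition), compound 1 `CNc1nc(/C=C/c2ccccc2)nc2ccsc12` gives > 1000000 nM, which is a limit. Compound 2 `CCCCNc1nc(/C=C/c2ccccc2)nc2ccsc12` gives > 1000000 nM, also a limit, so it has no numeric standing in the series; see (the limit of > 1000000 nM in this assay, at which 2 of the 2 values shown sit). Compound 3 `CC(C)CNc1nc(/C=C/c2ccccc2)nc2ccsc12` has isopropyl in place of propyl on a saturated chain carbon bound to a nitrogen on an aromatic ring, butyl to isobutyl: isopropyl in place of propyl on a saturated chain carbon bound to a nitrogen on an aromatic ring. Among the measured compounds shown here, the one measured step bearing on this, a step that the two limits leave unreadable from compound 1 to compound 2, has no readable size, so no step beyond the scatter is expected in this assay. The expected change is a number no higher from compound 2 to compound 3 (the limit leaves the size open). The estimate for compound 3 is 1000000 nM, with a range of 400000 nM to 2500000 nM.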

Compound 3, half-maximal inhibitory concentration: > 1000000 nM
Compound 3: no number, only a limit (the forecaster's own chance of this, stated with the estimate: 85%); the middle value sits exactly at the limit.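

Among the compounds shown here, compound 1, compound 2 and compound 3 all sit at a limit, so no step among them can be read in this assay: the limit of > 1000000 nM in this assay, at which 3 of the 3 values shown sit. The compounds shown leave open whether butyl and isobutyl differ at all in this read-out.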